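The source may report more compounds than this note shows. Statements on the series, on what has been measured and on what is new or still open speak of the compounds shown alone.

Measured so far in a functional assay on HT-29 cells (Homo sapiens) for cytotoxicity; a higher number here means that more compound is needed for the effect, a lower number that less compound is needed:

compound 1 `COc1cc(/C=C/c2ccc(C(C)C)cc2)cc(OC)c1OC` gives 6.8 uM
compound 2 `COc1cc(/C=C\c2ccc(C(C)(C)C)cc2)cc(OC)c1OC` gives 8.8 uM
compound 3 `CCOc1ccc(/C=C/c2cc(OC)c(OC)c(OC)c2)cc1` gives 1.49 uM

Compound 3 has the lowest number of the three, with its gaps to compound 1 and compound 2 both beyond the scatter. The next compound is compound 4 `COc1cc(/C=C/c2ccc(C(C)(C)C)cc2)cc(OC)c1OC`, which has tert-butyl in place of ethoxy on an aromatic carbon, para to a large group (tert-butyl in place of ethoxy on an aromatic carbon). Within the data shown here, the one measured step that bears on this is a 4.6-fold lower number from compound 1 to compound 3 (0.66 log units; beyond the scatter), a modest step with ethoxy in place of isopropyl on an aromatic carbon. Compound 4 moves away from ethoxy, so a step of similar size towards a higher number is expected in this assay. Compound 2 also carries tert-butyl and gives 8.8 uM as indirect support. Among the measured compounds shown here, no measured step isolates tert-butyl, so the range stays wide. The expected change is a 4.7-fold higher number from compound 3 to compound 4 (0.67 log units; beyond the scatter). Compound 4 is estimated at 7 uM, with an expected range of 3 uM to 16 uM.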

Compound 4, concentration for half-maximal effect: > 25 uM
Compound 4 ended at the assay's limit (the forecaster's own chance of this, stated with the estimate: 3%); middle value at least 3.5-fold (0.55 log units) away from the limit.
By their numbers in this assay, from the lowest: compound 3; then compounds 1 and 2 (each within the scatter of the next). At a limit, above all of these: compound 4.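

In this assay compound 4 gives > 25 uM, which is a limit of the assay and not a number: the limit of > 25 uM in this assay, at which 1 of the 4 values shown sits. On this aromatic carbon, para to a large group, tert-butyl in place of ethoxy gives an at least 16-fold higher number from compound 3 to compound 4 (1.22 log units; beyond the scatter), a large step, and the added methyl on the saturated chain carbon alone gives an at least 3.6-fold higher number from compound 1 to compound 4 (0.56 log units; beyond the scatter), so one extra carbon on the isopropyl group already separates the two compounds beyond the scatter. The double bond counts as well, with an at least 2.8-fold higher number from compound 2 to compound 4 (0.45 log units; beyond the scatter), the Z form holding a number within the assay's range while the E form stands at the limit: the fact that compounds 2 and 4 differ only in the configuration as drawn.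

Going by these compounds, how far compound 4 lies past the limit stays open, and with it the full size of all three steps. Also open, on these data alone, is how an amine or a propoxy chain would behave at this place, and whether ethoxy keeps its number with the Z double bond.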